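From Methoxy to Hydroxy on Compound 2

The compounds below may be only part of what the source reports. "The series", "measured", "known", "first", "only" and "open" are said of these compounds alone.

In a functional assay on SW-620 cells (Homo sapiens) for cytotoxicity, read by MTT assay, with a stated time of 72 h (a higher number here means a weaker inhibitor, a lower number a stronger inhibitor), compound 1 (`COc1ccc(/C=C2\CCC/C(=C\c3ccc(Cl)cc3)C2=O)cc1OC`) gives 5900 nM and compound 2 (`COc1cc(/C=C2\CCC/C(=C\c3ccc(OC)c(OC)c3)C2=O)ccc1O`) gives 4500 nM and so sits within the scatter of compound 1. Compound 3 (`COc1ccc(/C=C2\CCC/C(=C\c3ccc(O)c(O)c3)C2=O)cc1OC`) carries hydrogen in place of methyl on an oxygen on an aromatic ring, turning 4-hydroxy-3-methoxyphenyl into 3,4-dihydroxyphenyl. Among the measured compounds shown here, the only measured step bearing on this, a 1.3-fold lower number from compound 1 to compound 2 (0.12 log units; within the scatter) for 4-hydroxy-3-methoxyphenyl in place of 4-chlorophenyl, gives no sign of a large change in this assay here. The expected step of a 1.3-fold lower number from compound 2 to compound 3 (0.11 log units; within the scatter) therefore stays within the scatter. Compound 3 is estimated at 3500 nM (expected range 1300 nM to 8500 nM).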

Compound 3, half-maximal inhibitory concentration: 10500 nM
Compound 3: middle estimate off by 3.0-fold (0.48 log units), on the low side, outside the stated range (above it).
By their numbers in this assay, from the lowest: compounds 2, 1 and 3 (each within the scatter of the next, the first and the last beyond it).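

In this assay, replacing methoxy with hydroxy, which turns 4-hydroxy-3-methoxyphenyl into 3,4-dihydroxyphenyl, moves the number beyond the scatter, though only modestly (a 2.3-fold higher number from compound 2 to compound 3 (0.37 log units; beyond the scatter)). This is the first step shown to do so, whereas 3,4-dihydroxyphenyl in place of 4-chlorophenyl stays within it (a 1.8-fold higher number from compound 1 to compound 3 (0.25 log units; within the scatter)). No evidence is available to explain this result. The compounds shown leave open whether ethoxy or an amine in place of this hydroxy would keep the number nearer that of compound 2.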